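Clearance expected for the methyl analogue of compound 3

A few compounds are considered here, and "the series" means these few. Any claim that something is new, unique, unknown or untested is made for them only; others in the source may bear on it.

Measured in an ADME assay on microsomes from liver (Homo sapiens) for pharmacokinetics, read by LC-MS, with a stated time of 60 min, tested at 1 uM; a higher number here means faster removal of the compound, a lower number slower removal:
- compound 1 `O=C(NCc1ccc(S(=O)(=O)c2cccc(C(F)(F)F)c2)cc1)N1Cc2ccncc2C1`: 14 mL/min/kg
- compound 2 `O=C(NCc1ccc(S(=O)(=O)C2CCCOC2)cc1)N1Cc2ccncc2C1`: 7 mL/min/kg
- compound 3 `CCC(=O)N1CCC(S(=O)(=O)c2ccc(CNC(=O)N3Cc4ccncc4C3)cc2)CC1`: 11 mL/min/kg

Compound 3, at 11 mL/min/kg, stands within the scatter of both other compounds. The data show a 1.3-fold lower number from compound 1 to compound 3 (0.10 log units; within the scatter) and a 1.6-fold higher number from compound 2 to compound 3 (0.20 log units; within the scatter).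

Compound 4 `CN1CCC(S(=O)(=O)c2ccc(CNC(=O)N3Cc4ccncc4C3)cc2)CC1` differs from compound 3 in one place: methyl in place of propanoyl on an amine nitrogen in a ring. In short, compound 4 carries a methyl group where compound 3 carries a propanoyl group.

Among the compounds with values here, no measured step makes this change alone. All three replace the whole group on the sulfonyl sulfur, and a 2.0-fold lower number from compound 1 to compound 2 (0.30 log units; within the scatter) also stays within the scatter, as do the two steps to compound 3. These steps give no ground for a particular direction, so no step beyond the scatter is expected in this assay. The expected step is a 1.1-fold lower number from compound 3 to compound 4 (0.04 log units; within the scatter).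

The estimated value for compound 4 is 10 mL/min/kg, with an expected range of 5 mL/min/kg to 20 mL/min/kg.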

Compound 4, clearance: 11 mL/min/kg
Compound 4: middle estimate off by 1.1-fold (0.04 log units), on the low side; the range from low to high includes it.
By their numbers in this assay, from the lowest: compounds 2, 3, 4 and 1 (each within the scatter of the next).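

In this assay, the change at this position alone gives no change at the digits printed from compound 3 to compound 4 (within the scatter) and so shows that, on the amine nitrogen in the ring, methyl and propanoyl cannot be told apart in this read-out. The new 1-methylpiperidin-4-yl group also stays within the scatter of the other groups on the sulfonyl sulfur, with a 1.6-fold higher number from compound 2 to compound 4 (0.20 log units; within the scatter) and a 1.3-fold lower number from compound 1 to compound 4 (0.10 log units; within the scatter) as its steps, just as 1-propanoylpiperidin-4-yl did. Nothing measured here offers a reason for this result.

The compounds shown leave open whether the free ring amine, with only a hydrogen on that nitrogen, or a carboxylic acid on a short chain there would give a step beyond the scatter. They also leave open whether a longer acyl chain, such as hexanoyl, would do so.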